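The compounds below may be only part of what the source reports. "The series", "measured", "known", "first", "only" and "open" are said of these compounds alone.

Measured so far in an ADME assay on microsomes from liver (Rattus norvegicus) for metabolic stability; on this read-out lower numbers stand for a shorter-lived compound and higher numbers for a longer-lived compound:

Compound 1 `CC(C)[C@H](C[C@H]1OC(=O)NC1=O)c1ccc(-c2ccc3cccc(F)c3c2)[nH]c1=O`: 0.95 h
Compound 2 `CC(C)(/C=C1\OC(=O)NC1=O)c1ccc(-c2ccc3cccc(F)c3c2)[nH]c1=O`: > 3 h (a limit of the assay, not a number)

Compound 1, at 0.95 h, carries the only exact half-life here, so it is the natural starting point. Compound 3 `CC(C)[C@H](C[C@H]1SC(=O)NC1=O)c1ccc(-c2ccc3cccc(F)c3c2)[nH]c1=O` has yet to be measured. It differs from compound 1 in one place, where 2,4-dioxo-1,3-thiazolidin-5-yl stands in place of 2,4-dioxo-1,3-oxazolidin-5-yl on a saturated chain carbon, two bonds along the chain from an aromatic carbon: 2,4-dioxo-1,3-thiazolidin-5-yl in place of 2,4-dioxo-1,3-oxazolidin-5-yl on a saturated chain carbon, two bonds along the chain from an aromatic carbon. Among the measured compounds shown here, no measured pair shows this exchange, so the expectation rests on compound 1 at 0.95 h alone. In this assay, no change beyond the usual scatter is expected, and the estimated step is a 1.1-fold higher number from compound 1 to compound 3 (0.02 log units; within the scatter). The expected half-life of compound 3 is 1 h, with an estimated range from 0.5 h to 2.2 h.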

Compound 3, half-life: 0.143 h
Beside the measured number, compound 3's estimate is 7.0-fold (0.84 log units) above it; the whole stated range lies above it.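

In this assay, a very small exchange on a saturated chain carbon, two bonds along the chain from an aromatic carbon, proves enough to matter: putting 2,4-dioxo-1,3-thiazolidin-5-yl in place of 2,4-dioxo-1,3-oxazolidin-5-yl gives a 6.6-fold lower number from compound 1 to compound 3 (0.82 log units; beyond the scatter). The two groups match in heavy-atom count, ring size, and hydrogen-bond donors and acceptors, differing only in one sulfur taking the place of one oxygen, so those counts alone do not settle the half-life here. This is also the first pair shown that differs in just one place, and it marks this group as a sensitive point in the structure.

Nothing shown explains why the half-life moves with this exchange. On these data alone, how a carboxylic acid or a primary amide would fare at this place, and whether the same exchange would act alike on the chain of compound 2, stays open.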